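The source may report more compounds than this note shows. Statements on the series, on what has been measured and on what is new or still open speak of the compounds shown alone.

Of the compounds shown here, two have been measured. Compound 1 `Cc1cc(O)cc(-c2nn(CC#N)cc2-c2ccnc(-c3ccc(Oc4ccccc4)cc3)c2)c1` gives 48600 nM in a functional assay on NCI-H322M cells (Homo sapiens) for inhibition, read by sulforhodamine B assay, with a stated time of 48 h; a higher number here means that more compound is tolerated, a lower number that less compound is tolerated. Compound 2 `COc1cc(C)cc(-c2nn(CC#N)cc2-c2ccnc(-c3ccc(N(C)C)cc3)c2)c1` reaches the limit of the assay and is reported as > 100000 nM, a limit rather than a number. Where compound 2 stands is therefore fixed only at one end, at the limit of > 100000 nM in this assay, at which 1 of the 2 values shown sits, and the two values shown do not allow a step to be measured between them.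

Compound 3 `Cc1cc(O)cc(-c2nn(CC#N)cc2-c2ccnc(-c3ccc(N(C)C)cc3)c2)c1` is not yet measured. It is derived from compound 2 by hydrogen in place of methyl on an oxygen on an aromatic ring; in words, hydrogen in place of methyl on an oxygen on an aromatic ring. Among the measured compounds shown here, no measured pair shows what this change does here. The expected step from compound 2 to compound 3 is an at least 1.4-fold lower number from compound 2 to compound 3 (0.15 log units; that floor lies within the scatter), a shift toward less compound tolerated, small and near the scatter. For compound 3 the estimate is 70000 nM, with a range from 30000 nM to 150000 nM.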

Compound 3, concentration lethal to 50% of the cells: > 100000 nM
Compound 3 ended at the assay's limit; the forecaster's own chance of this, stated with the estimate: 40%; middle value at least 1.4-fold (0.15 log units) away from the limit.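

Among the compounds shown here, with the hydroxy group held constant, dimethylamino in place of phenoxy on an aromatic carbon gives an at least 2.0-fold higher number from compound 1 to compound 3 (0.31 log units; beyond the scatter) in this assay and is the first readable step. It places the phenoxy compound, compound 1, on the side of less compound tolerated. Methoxy to hydroxy, by contrast, cannot be read, because compound 2 and compound 3 both stand at a limit rather than at a number: the limit of > 100000 nM in this assay, at which 2 of the 3 values shown sit.

As far as these compounds go, whether methoxy to hydroxy changes anything at all remains open, and a phenoxy compound carrying methoxy would be the pair that could show it. Also open, from the compounds shown here alone, is how far the step depends on the phenoxy group itself, which a benzyloxy group or a simple amine on the same aromatic carbon would test.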